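The source may hold more compounds than are shown below. What is called first, only, known or untested is meant among the compounds shown, and "the series" means these compounds.

Measured so far:
- compound 1, `CC(C)C[C@H](NC(=O)CCN(C)C)c1cc(C(F)(F)F)ccc1N1CCN(C(=O)[C@H]2CSC[C@@H]2c2ccc(Cl)cc2)CC1`, in an assay on HEK293 cells for displacement of a labelled ligand from Melanocortin receptor 4 (Homo sapiens) (on this read-out lower numbers stand for stronger inhibition and higher numbers for weaker inhibition), compound 1 gives 130 nM.
- compound 2, `CC(C)C[C@H](NC(=O)CCN(C)C)c1cc(C(F)(F)F)ccc1N1CCN(C(=O)C2COCC2c2ccc(Cl)cc2)CC1`, in this assay compound 2 gives 71 nM.

Going by the values given here, compound 2 holds one end of these two numbers; its only neighbour is compound 1, and the step of a 1.8-fold lower number from compound 1 to compound 2 (0.26 log units; within the scatter) lies within the scatter, so the two are not separated.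

The next compound is compound 3, `CC(C)C[C@H](NC(=O)CCN(C)C)c1cc(C(F)(F)F)ccc1N1CCN(C(=O)[C@H]2CCO[C@@H]2c2ccc(Cl)cc2)CC1`, not yet measured. Its structural change from compound 2 is 2-(4-chlorophenyl)oxolan-3-yl in place of 4-(4-chlorophenyl)oxolan-3-yl on a carbonyl carbon; the two have the same atoms, joined differently, with the chlorophenyl ring moved from one carbon of the oxolane ring to another, the group sitting on a carbonyl carbon whose other neighbour is an amide-type nitrogen in a ring.

Among the compounds with values here, only one measured step exists, a 1.8-fold lower number from compound 1 to compound 2 (0.26 log units; within the scatter), and it concerns the heteroatom of the five-membered ring, not the point where the chlorophenyl ring is joined. Within the data shown here, no measured step bears directly on the change to compound 3. The expectation in this assay is therefore a step of no clear direction and of a size not clearly beyond the scatter, a 1.5-fold higher number from compound 2 to compound 3 (0.19 log units; within the scatter), with wide uncertainty. Compound 3 is estimated at 110 nM, range 30 nM to 450 nM.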

Compound 3, inhibition constant: 200 nM
Compound 3: middle estimate off by 1.8-fold (0.26 log units), on the low side, within the range that was stated.
By their numbers in this assay, from the lowest: compounds 2, 1 and 3 (each within the scatter of the next, the first and the last beyond it).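

Moving the chlorophenyl ring from 4-(4-chlorophenyl)oxolan-3-yl to 2-(4-chlorophenyl)oxolan-3-yl on the carbonyl carbon gives a 2.8-fold higher number from compound 2 to compound 3 (0.45 log units; beyond the scatter) in this assay and is the first step in the series beyond the scatter, so the point of attachment on the oxolane ring registers in this read-out, although only modestly. The comparison with the thiolane-bearing compound gives a 1.5-fold higher number from compound 1 to compound 3 (0.19 log units; within the scatter) and does not separate the pair, so this shift sets compound 3 apart from compound 2 only, and the order across the series rests on that single step. Nothing accompanying these numbers accounts for the step.

The entering group carries 2 defined stereocentres, while none are shown for the group it replaces, so how much of the step belongs to the attachment point and how much to the stereochemistry remains open, as does how the other stereoisomers of the 2-(4-chlorophenyl)oxolan-3-yl group would read. Also open, on these data alone, is whether the attachment point matters in the same way with a 2-(4-chlorophenyl)thiolan-3-yl group, or with a ring amine nitrogen in place of the oxygen.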